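Methoxy for fluoro on the benzyl group of compound 2

A few compounds are considered here, and "the series" means these few. Any claim that something is new, unique, unknown or untested is made for them only; others in the source may bear on it.

Measured compounds:
Compound 1 `COc1ccc(CNc2nc3cc(N)cc(N)c3nc2-c2ccccc2)cc1OC` — < 100000 nM
Compound 2 `Nc1cc(N)c2nc(-c3ccccc3)c(NCc3ccc(F)cc3)nc2c1` — 40700 nM

Within the data shown here, in a functional assay on SF-268 cells (Homo sapiens) for inhibition, read by sulforhodamine B assay, with a stated time of 48 h (a lower number here means that less compound is tolerated, a higher number that more compound is tolerated), compound 2 gives 40700 nM, the only plain number in this set. For compound 1 this assay reports a limit, < 100000 nM, rather than a number. The step that the limit leaves unreadable from compound 1 to compound 2 therefore cannot be sized, because the limit of < 100000 nM in this assay, at which 1 of the 2 values shown sits, leaves the true value of compound 1 unreadable.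

Compound 3 `COc1ccc(CNc2nc3cc(N)cc(N)c3nc2-c2ccccc2)cc1` differs from compound 2 in one place: methoxy in place of fluoro on an aromatic carbon. Among the measured compounds shown here, the only measured step, from compound 1 to compound 2, exchanges the whole benzyl substitution pattern and is masked by the limit, so nothing measured here speaks for a direction in this assay. The expectation is accordingly a step of no size beyond the scatter, a 1.2-fold higher number from compound 2 to compound 3 (0.09 log units; within the scatter), with the upper part of the range reaching the limit that this assay set for compound 1. Compound 3 is expected at 50000 nM, within 20000 nM to 120000 nM.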

Compound 3, concentration lethal to 50% of the cells: 49000 nM
For compound 3 the middle estimate is 1.0-fold (0.01 log units) above the measured one; the range from low to high includes it.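

Among these compounds, compound 2 and compound 3 give the first readable step at this position: in this assay, methoxy in place of fluoro gives a 1.2-fold higher number from compound 2 to compound 3 (0.08 log units; within the scatter) and so does not separate the two compounds. On an aromatic carbon para to a large group, then, the exchange of fluoro for methoxy, which adds one hydrogen-bond acceptor by the count of the two groups, shows no difference that this assay can resolve. The steps that start from compound 1 still cannot be read, so whether a second methoxy on the benzyl group matters stays unsettled, because compound 1 carries a limit and not a number: the limit of < 100000 nM in this assay, at which 1 of the 3 values shown sits.

With only fluoro and methoxy comparable at this position, the compounds shown leave open whether an amine, a carboxylic acid or a longer alkoxy chain there would give a number apart from these two. They also leave open whether a change elsewhere on the shared core, such as replacing the phenyl group, would move the number beyond the scatter.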